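Adding an amino group to a dichlorobenzimidazole anilide series

The compounds below may be only part of what the source reports. "The series", "measured", "known", "first", "only" and "open" are said of these compounds alone.

Of the compounds shown here, three sharing one core have been tested in an ADME assay on Vero cells (Chlorocebus sabaeus) for cytotoxicity; on this read-out higher numbers stand for lower toxicity in this test and lower numbers for higher toxicity in this test. Among the measured compounds shown here, compound 1 `COc1ccc(-c2nc3cc(Cl)c(Cl)cc3[nH]2)cc1` gives 30000 nM in this assay, and it is the only compound of the three to return an actual number. Compound 2 `O=[N+]([O-])c1ccc(-c2nc3cc(Cl)c(Cl)cc3[nH]2)cc1` reaches only the limit of >= 100000 nM in this assay. Compound 3 `CC(=O)Nc1ccc(-c2nc3cc(Cl)c(Cl)cc3[nH]2)cc1` likewise reaches only the limit of > 100000 nM in this assay. The steps from compound 1 are an at least 3.3-fold higher number from compound 1 to compound 2 (0.52 log units; beyond the scatter) and an at least 3.3-fold higher number from compound 1 to compound 3 (0.52 log units; beyond the scatter), both showing that replacing the methoxy group lowers toxicity at least somewhat.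

Compound 4 `COc1ccc(-c2nc3cc(Cl)c(Cl)cc3[nH]2)c(N)c1` keeps the methoxy group and differs from compound 1 by amino in place of hydrogen on an aromatic carbon. For the measured compounds named here, no measured step changes this place; the two known steps alter a different group, so they give only a loose guide. A small change that adds one polar atom on the outer ring is expected to leave this assay close to where compound 1 stands, with a modest lowering of toxicity at most. Compound 4 is therefore expected to give about 40000 nM in this assay, within a range of 15000 nM to 100000 nM, a step of a 1.3-fold higher number from compound 1 to compound 4 (0.12 log units; within the scatter).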

Compound 4, half-maximal cytotoxic concentration: 75000 nM
The estimate for compound 4 lay 1.9-fold (0.27 log units) below the measured number; low and high end bracket the measured number.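

Compound 1's earlier steps all replaced the methoxy group, whereas this one keeps it and adds an amino group on an aromatic carbon ortho to a large group and meta to that methoxy group. In this assay this addition gives a 2.5-fold higher number from compound 1 to compound 4 (0.40 log units; beyond the scatter), so a second place on the ring, and not only the methoxy position, can shift the read-out toward lower toxicity in this test. The data shown offer no explanation for this step.

Going by these compounds, it remains open whether a hydroxyl group, a methyl group or a longer chain on this same carbon would shift the number in the same direction. On these data alone, it also remains open whether the amino group would have any readable effect alongside the nitro group or the acetamido group.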